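Methoxy to ethoxy on the shared core

This account rests on a few compounds, and the source may have more. Where it says the series, first, only, none or still open, it means among the compounds named here.

Of the compounds shown here, two have been measured in an ADME assay on L929 cells (Mus musculus) for cytotoxicity, read by CCK-8 assay, with a stated time of 48 h, tested at 100 uM; a higher number here means a weaker effect of the compound at the concentration tested, a lower number a stronger effect. Compound 1 `COc1ccc(S(=O)(=O)N2CCN(c3ccccc3F)CC2)cc1S(=O)(=O)N1CCN(c2ccccc2F)CC1` gives 66.7% in this assay. Compound 2 `COc1ccc(S(=O)(=O)N2CCN(c3cccc(C)c3)CC2)cc1S(=O)(=O)N1CCN(c2cccc(C)c2)CC1` gives 66.7% in this assay. The two values are level at the digits shown, so compound 1 stands with its nearest neighbour, compound 2, within the scatter, and no order between them can be read from the numbers. For the measured compounds named here, compound 1 and compound 2 differ from each other in more than one place, so the pair offers no single step from which a size could be taken.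

Compound 3 `CCOc1ccc(S(=O)(=O)N2CCN(c3ccccc3F)CC2)cc1S(=O)(=O)N1CCN(c2ccccc2F)CC1` has not yet been measured in this assay. It differs from compound 1 by methyl in place of hydrogen on a saturated chain carbon bound to an oxygen on an aromatic ring. Going by the values given here, with no measured step available as a yardstick, the expectation rests on the change itself: a methyl entering on a saturated chain carbon bound to an oxygen on an aromatic ring, with methoxy becoming ethoxy, is expected to move the read-out little, and not beyond the scatter in either direction. The step of a number 0.7 percentage points lower from compound 1 to compound 3 (within the scatter) is therefore expected to be flat. Compound 3 is estimated at 66% in this assay, with a range from 50% to 82%.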

Compound 3, a percentage reported as activity, at one concentration (the size of the read-out at that concentration, not a potency): 3.7%
Estimate against measurement, compound 3: 62.3 percentage points above, outside the stated range (below it).
By their numbers in this assay, from the lowest: compound 3; then compounds 1 and 2 (each within the scatter of the next).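

In this assay the change from methoxy to ethoxy on the shared core gives a number 63 percentage points lower from compound 1 to compound 3 (beyond the scatter) and so shows that this position, a saturated chain carbon bound to an oxygen on an aromatic ring, is sensitive: one added methyl takes the series from a weaker to a much stronger effect at the concentration tested. Compound 1 and compound 2 could not show this, since they share the methoxy group, differ from each other in more than one place and stand level. Nothing available here explains why so small a change carries so large a step, and this remains a single pair on one substitution pattern.

Going by these compounds, it remains open whether the effect stays at ethoxy, grows further or falls away with a longer or branched chain such as propoxy or isopropoxy on the same oxygen. On these data alone, it is equally open whether methoxy to ethoxy gives a step of similar size on the core of compound 2, so no rule for the series can yet be drawn from this one step.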